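Chloro to methyl on the shared core: compound 4

The source may report more compounds than this note shows. Statements on the series, on what has been measured and on what is new or still open speak of the compounds shown alone.

Measured compounds in an assay on isolated protein for displacement of a labelled ligand from metabotropic glutamate receptor 5 (Homo sapiens), with a stated time of 60 min, tested at 1 uM; on this read-out higher numbers stand for more inhibition at the one concentration tested (going by the name of the read-out) and lower numbers for less inhibition:
- compound 1 `CC1CCN(c2c(S(=O)(=O)c3cccc(Cl)c3)cnc3ccc(Cl)cc23)CC1` gives 92%
- compound 2 `COc1cccc(S(=O)(=O)c2cnc3ccc(Cl)cc3c2N2CCC(C)CC2)c1` gives 87%
- compound 3 `CC1CCN(c2c(S(=O)(=O)c3ccc(C#N)cc3)cnc3ccc(Cl)cc23)CC1` gives 31%

Compound 2 stands second highest of the three numbers in this assay. Its nearest neighbour is compound 1, with a number 5 percentage points lower from compound 1 to compound 2 (within the scatter), and its furthest is compound 3, with a number 56 percentage points lower from compound 2 to compound 3 (beyond the scatter). The two large steps in the set both concern the aryl on the sulfonyl sulfur: a number 61 percentage points lower from compound 1 to compound 3 (beyond the scatter) and a number 56 percentage points lower from compound 2 to compound 3 (beyond the scatter). Compound 4 `COc1cccc(S(=O)(=O)c2cnc3ccc(C)cc3c2N2CCC(C)CC2)c1` has not been measured. It differs from compound 2 in one place: methyl in place of chloro on an aromatic carbon, the aromatic carbon belonging to the fused system of two rings.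

Going by the values given here, no measured step touches this part of the shared core. Among the compounds with values here, the only step that removes a chloro, a number 5 percentage points lower from compound 1 to compound 2 (within the scatter), sits on the ring bound to the sulfonyl sulfur and was within the scatter, so it is an indirect precedent at best. With no direct comparison, the expected step in this assay is small, at most a modest loss, and may well stay within the scatter. The step from compound 2 to compound 4 is expected to be a number 12 percentage points lower from compound 2 to compound 4 (beyond the scatter). Compound 4 is expected to give 75%, with a range from 45% to 95%.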

Compound 4, a percentage reported as inhibition, at one concentration (the size of the read-out at that concentration, not a potency): 96%
For compound 4 the middle estimate is 21 percentage points below the measured one; measured number above the stated range.
By their numbers in this assay, from the lowest: compound 3; then compounds 2, 1 and 4 (each within the scatter of the next).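

In this assay, going by these compounds alone, the first change at this part of the shared core, methyl in place of chloro on an aromatic carbon of the six-membered aromatic ring of carbon only, gives a number 9 percentage points higher from compound 2 to compound 4 (within the scatter). Within the data shown here, the chloro on this ring is therefore not needed to keep the read-out of the 3-methoxyphenyl sulfone at this one concentration, and methyl serves here as a workable replacement, something the earlier compounds could not show since all of them carry chloro at this place. This rests on a single pair with one aryl on the sulfonyl sulfur, and no measurement shown here gives a reason for the result.

Still open, from the compounds shown here alone, is whether methyl at this place holds with the 4-cyanophenyl group of compound 3 , which gives 31%, and whether an amine, a carboxylic acid or a longer chain such as propyl is accepted on the same carbon. A percentage at one concentration also leaves any difference in potency between the chloro and methyl compounds unresolved, so a full concentration-response comparison of that pair remains the next useful reading.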